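A Second 3-Methylbut-2-en-1-yl Group on a Longer Chain

The source may hold more compounds than are shown below. What is called first, only, known or untested is meant among the compounds shown, and "the series" means these compounds.

In an assay on isolated protein for inhibition of polyamine oxidase 1 (Zea mays), read by spectrophotometry, using a Dixon plot, at pH 6.5 (a lower number here means a stronger inhibitor, a higher number a weaker inhibitor), three compounds have been measured:
compound 1 `CC(C)=CCNC(=N)NCCCCNC(=N)NCC=C(C)C` gives 1500 nM;
compound 2 `CC(C)=CCNC(=N)NCCCCNC(=N)N` gives 700 nM;
compound 3 `CC(C)=CCNC(=N)NCCCCCCCCNCCCCCCCCNC(=N)N` gives 3 nM.

Compound 3 stands lowest of the three, well apart from the other two. Compound 2 and compound 3 differ in more than one place, so the difference between their cores is not broken down here.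

Within the shorter pair, the change from compound 2 to compound 1 is 3-methylbut-2-en-1-yl in place of hydrogen on an amine nitrogen. This made a step of a 2.1-fold higher number from compound 2 to compound 1 (0.33 log units; beyond the scatter), a modest weakening.

Compound 4 `CC(C)=CCNC(=N)NCCCCCCCCNCCCCCCCCNC(=N)NCC=C(C)C` carries the same change on the core of compound 3: 3-methylbut-2-en-1-yl in place of hydrogen on an amine nitrogen. The surroundings of the place are described in the same words for both pairs, so this is the same change, now on the longer core.

Among the compounds with values here, because the earlier step was a 2.1-fold higher number from compound 2 to compound 1 (0.33 log units; beyond the scatter), a step of similar size is expected here, a 2.0-fold higher number from compound 3 to compound 4 (0.30 log units; within the scatter), with the reservation that only one example of this change is known and the core differs considerably. On that basis compound 4 is estimated at 6 nM in this assay, expected to lie between 2.5 nM and 15 nM.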

Compound 4, inhibition constant: 1.7 nM
Compound 4: the middle estimate sits 3.5-fold (0.55 log units) above what was measured, outside the stated range (below it).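

In this assay, the new step is a 1.8-fold lower number from compound 3 to compound 4 (0.25 log units; within the scatter), so adding 3-methylbut-2-en-1-yl on the longer core gives no change that can be told apart from ordinary repeat variation. Set beside the earlier step, this shows that the effect of the change did not carry over unaltered from the shorter core to the longer one: the same change on two cores in this assay, a 2.1-fold higher number (0.33 log units; beyond the scatter) from compound 2 to compound 1 and a 1.8-fold lower number (0.25 log units; within the scatter) from compound 3 to compound 4, 3.8-fold (0.58 log units) apart, beyond the scatter of two such steps

Within the data shown here, it does not show why the two cores respond differently, and with only one pair on each core, it cannot say how the change would behave on any other core.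

The compounds shown leave open whether a different group on the same amine nitrogen, such as methyl or benzyl, would also respond differently on the two cores. They also leave open which part of the longer core matters, for instance whether a core with a chain of intermediate length would respond more like the shorter core or the longer one.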